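Cytotoxicity on Vero cells along the acyl chain series

A few compounds are considered here, and "the series" means these few. Any claim that something is new, unique, unknown or untested is made for them only; others in the source may bear on it.

Three compounds share one core and differ only in the chain on the amide. Compound 1 `CC(=O)Nc1nc(N)nc2c1ncn2[C@H]1CO[C@@H](CO)O1` carries the shortest chain. In an ADME assay on Vero cells (Chlorocebus sabaeus) for cytotoxicity (a higher number here means that more compound is tolerated, a lower number that less compound is tolerated), compound 1 gives > 100000 nM, which is a limit of the assay and not a number. Compound 2 `CCCCCC(=O)Nc1nc(N)nc2c1ncn2[C@H]1CO[C@@H](CO)O1` follows. In this assay compound 2 gives > 100000 nM, again a limit. Compound 3 `CCCCCCCC(=O)Nc1nc(N)nc2c1ncn2[C@H]1CO[C@@H](CO)O1` comes next. In this assay compound 3 gives > 100000 nM, also a limit. The steps along the chain, a step that the two limits leave unreadable from compound 1 to compound 2, a step that the two limits leave unreadable from compound 1 to compound 3 and a step that the two limits leave unreadable from compound 2 to compound 3, are therefore unreadable in size, since all three values sit at the limit of > 100000 nM in this assay, at which 3 of the 3 values shown sit.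

Compound 4 `CCCCCCCCCCCCCC(=O)Nc1nc(N)nc2c1ncn2[C@H]1CO[C@@H](CO)O1` extends the chain once more: hexyl in place of hydrogen on a saturated chain carbon, seven bonds along the chain from a carbonyl carbon. Within the data shown here, every step so far lies at the same limit, so no size or direction of change is readable, and the expectation for the step from compound 3 to compound 4 is a limit once more, estimated as a number no higher from compound 3 to compound 4 (the limit leaves the size open). Compound 4 is expected to give about 100000 nM in this assay, with a range from 30000 nM to 300000 nM.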

Compound 4, half-maximal cytotoxic concentration: 7700 nM
The estimate for compound 4 lay 13-fold (1.11 log units) above the measured number; the whole stated range lies above it.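

In this assay, the chain on the amide now has a readable effect: hexyl in place of hydrogen on a saturated chain carbon, seven bonds along the chain from a carbonyl carbon, gives an at least 12-fold lower number from compound 3 to compound 4 (1.11 log units; beyond the scatter). Taken over a longer stretch of the chain, the series shows an at least 12-fold lower number from compound 2 to compound 4 (1.11 log units; beyond the scatter). Lengthening the chain therefore does not stay without a readable change to the end of the series, and compound 4 alone stands off the value shared by the other compounds: the limit of > 100000 nM in this assay, at which 3 of the 4 values shown sit.

Going by these compounds, at which chain length between those of compound 3 and compound 4 the number first comes off the limit stays open. Also open, on these data alone, is whether a longer chain lowers the number further, and whether an amine or a carboxylic acid at the end of the chain of compound 4 would restore the limit.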